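The source may report more compounds than this note shows. Statements on the series, on what has been measured and on what is new or still open speak of the compounds shown alone.

Measured in a functional assay on A549 cells (Homo sapiens) for antiproliferative activity, read by MTT assay, with a stated time of 72 h (a higher number here means a weaker inhibitor, a lower number a stronger inhibitor), so far
Compound 1 `COc1cc(-n2cnc3ccc(-c4ccc(C)cc4F)cc32)cc(OC)c1OC` gives > 10000 nM as a limit of the assay
Compound 2 `COc1ccc(-c2ccc3ncn(-c4cc(OC)c(OC)c(OC)c4)c3c2)cc1F` gives 1430 nM as a number
Compound 3 `COc1cc(-n2cnc3ccc(-c4cccc(Cl)c4)cc32)cc(OC)c1OC` gives 7050 nM as a number

Of the two true numbers, the lower belongs to compound 2. Compound 4 `COc1cc(-n2cnc3ccc(-c4cccc(C)c4)cc32)cc(OC)c1OC` is unmeasured and differs from compound 2 as follows (3-methylphenyl in place of 3-fluoro-4-methoxyphenyl on an aromatic carbon), with 3-methylphenyl in place of 3-fluoro-4-methoxyphenyl on an aromatic carbon.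

Within the data shown here, two measured steps bear on this change. The closest is a 4.9-fold higher number from compound 2 to compound 3 (0.69 log units; beyond the scatter) and it removes the same 3-fluoro-4-methoxyphenyl in favour of 3-chlorophenyl. The other is an at least 6.9-fold lower number from compound 1 to compound 2 (0.84 log units; beyond the scatter) and it rests on a limit, so its true size is open. Among these three compounds, neither one without 3-fluoro-4-methoxyphenyl matches compound 2, and none goes against this. A modest rise is therefore expected in this assay for this change, similar in size to the step to compound 3. The estimated change is a 4.2-fold higher number from compound 2 to compound 4 (0.62 log units; beyond the scatter) and points towards weaker inhibition. For compound 4 the estimated value is 6000 nM (expected range 2800 nM to 10000 nM).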

Compound 4, half-maximal inhibitory concentration: 3820 nM
Estimate against measurement, compound 4: 1.6-fold (0.20 log units) above, and the stated range covers the measured number.
By their numbers in this assay, from the lowest: compound 2; then compounds 4 and 3 (each within the scatter of the next). At a limit, above all of these: compound 1.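

In this assay, 3-fluoro-4-methoxyphenyl now holds its edge over a second replacement, 3-methylphenyl, with a 2.7-fold higher number from compound 2 to compound 4 (0.43 log units; beyond the scatter), so the standing of compound 2 no longer rests on the 3-chlorophenyl comparison alone. Methyl in place of chloro gives no readable difference on this ring, with a 1.8-fold lower number from compound 3 to compound 4 (0.27 log units; within the scatter). The step from 2-fluoro-4-methylphenyl to 3-methylphenyl, an at least 2.6-fold lower number from compound 1 to compound 4 (0.41 log units; beyond the scatter), is only a floor, as it starts from a limit of the assay: the limit of > 10000 nM in this assay, at which 1 of the 4 values shown sits.

Still open, as far as these compounds go, is whether the fluoro or the methoxy of 3-fluoro-4-methoxyphenyl carries the gap, a question that a 4-methoxyphenyl or a 3-fluorophenyl at this position would bear on. From the compounds shown here alone, how an amine or a carboxylic acid on this ring would read in this assay also remains open.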